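Series notes: aryl change next to the ring nitrogen

This account rests on a few compounds, and the source may have more. Where it says the series, first, only, none or still open, it means among the compounds named here.

Compound 2 `Cc1cccc(-c2cc(-c3ccoc3)cc(-c3ccc(Cl)s3)n2)c1` gives 2.6% in an assay on isolated protein for inhibition of DNA topoisomerase 1 (Homo sapiens), with a stated time of 30 min, tested at 100 uM (a lower number here means less inhibition, a higher number more inhibition at the concentration tested (going by the name of the read-out)), the lower of the two numbers on hand, though compound 1 `Clc1ccc(-c2cc(-c3ccoc3)cc(-c3ccco3)n2)s1` at 9.6% lies within the scatter of it. Compound 3 `Clc1ccc(-c2cc(-c3ccoc3)cc(-c3ccccc3Cl)n2)s1` differs from compound 2 by 2-chlorophenyl in place of 3-methylphenyl on an aromatic carbon. Among the measured compounds shown here, the one measured step that bears on this, a number 7 percentage points lower from compound 1 to compound 2 (within the scatter), changed the same position and stayed within the scatter. For compound 3 the expected step is therefore a number 2.4 percentage points higher from compound 2 to compound 3 (within the scatter), nothing beyond the scatter. Compound 3 is estimated at 5%, with a range from -8% to 18%.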

Compound 3, a percentage reported as inhibition, at one concentration (the size of the read-out at that concentration, not a potency): 0%
Estimate against measurement, compound 3: 5 percentage points above, and the stated range covers the measured number.
By their numbers in this assay, from the lowest: compounds 3, 2 and 1 (each within the scatter of the next).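

In this assay the position next to the ring nitrogen now holds a third group: 2-chlorophenyl in place of 3-methylphenyl gives (a number 2.6 percentage points lower from compound 2 to compound 3 (within the scatter)), and 2-chlorophenyl in place of furan-2-yl gives (a number 9.6 percentage points lower from compound 1 to compound 3 (within the scatter)). Furan-2-yl, 3-methylphenyl and 2-chlorophenyl at this position therefore cannot be told apart in this read-out. Nothing on hand accounts for these numbers. On these data alone, whether an amine or a carboxylic acid here would give a step beyond the scatter stays open. So does the contribution of the 5-chlorothiophen-2-yl and furan-3-yl groups.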